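The source may report more compounds than this note shows. Statements on the series, on what has been measured and on what is new or still open speak of the compounds shown alone.

Compound 1 `COC(=O)[C@]1(Cc2ccc3c(c2)C[C@H](O)C(C)(C)O3)OC(=O)C(O)=C1c1ccc(O)cc1` was examined in a functional assay on HT-29 cells (Homo sapiens) for antiproliferative activity, read by CCK-8 assay, with a stated time of 24 h; on this read-out higher numbers stand for weaker inhibition and lower numbers for stronger inhibition. In this assay compound 1 gives > 20000 nM, which is a limit of the assay rather than a measured number. A second member of the series, compound 2 `COC(=O)[C@]1(Cc2ccc3c(c2)C[C@H](C(C)(C)O)O3)OC(=O)C(O)=C1c1ccc(O)cc1`, was run in this assay as well. In this assay compound 2 gives > 20000 nM, again a limit and not a number. Compound 1 therefore stands at the edge of what the assay can report, and the same is true of everything else shown: the limit of > 20000 nM in this assay, at which 2 of the 2 values shown sit. With only limits in hand, no order between compound 1 and compound 2 can be read from the numbers.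

The unmeasured compound 3 `COC(=O)[C@]1(Cc2ccc3c(c2)CCC(C)(C)O3)OC(=O)C(O)=C1c1ccc(O)cc1` differs from compound 1 by hydrogen in place of hydroxy on a saturated ring carbon. Among the measured compounds shown here, no pair of measured compounds that differ in a single place is available, so the size of such a step has not been observed here. Because compound 1 already sits at the limit of > 20000 nM, the expectation is that removing the hydroxy leaves the result at or beyond that limit, giving an expected step that the limit leaves unreadable from compound 1 to compound 3. Compound 3 is accordingly estimated at 30000 nM, with a likely span from 10000 nM to 100000 nM, and most probably reported only as a limit once more.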

Compound 3, half-maximal inhibitory concentration: > 20000 nM
Compound 3: a limit, no number (the forecaster's own chance of this, stated with the estimate: 85%); the middle value is on the limit's open side.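

No step can be read from compound 1 to compound 3, the swap of hydroxy for hydrogen, because both results are limits and not numbers: the limit of > 20000 nM in this assay, at which 3 of the 3 values shown sit.

The compounds shown leave open how strongly any of them acts in this assay, and whether the hydroxy on the saturated ring carbon matters there at all.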